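This account rests on a few compounds, and the source may have more. Where it says the series, first, only, none or still open, it means among the compounds named here.

Measured so far:
compound 1 `CCOC(=O)c1ccc(-c2nn(Cc3ccc(F)cc3)c3ccccc23)cc1` — > 10000 nM
compound 2 `CCCOC(=O)c1ccc(-c2nn(Cc3ccccc3)c3ccccc23)cc1` — > 10000 nM

In a functional assay on cells (Platelet, Homo sapiens) for inhibition (a higher number here means a weaker inhibitor, a lower number a stronger inhibitor), compound 1 gives > 10000 nM, which is a limit of the assay rather than a number. Compound 2 in this assay gives > 10000 nM, again a limit and not a number. Going by the values given here, compound 2 therefore stands at the limit of > 10000 nM in this assay, at which 2 of the 2 values shown sit, and the two values show only that both compounds sit at that limit; no ordering between them can be read from this.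

Compound 3 `CCOC(=O)/C=C/c1ccc(-c2nn(Cc3ccccc3)c3ccccc23)cc1` has not yet been measured in this assay. It differs from compound 2 in a single place: 2-(ethoxycarbonyl)ethenyl in place of propoxycarbonyl on an aromatic carbon. Among the compounds with values here, no step between two measured compounds is available here, since both measured values stop at the limit.

For compound 3 the step that the limit leaves unreadable from compound 2 to compound 3 is expected to be small, or none beyond the usual scatter. Compound 3 is expected to give about 15000 nM in this assay, with a range from 4000 nM to 60000 nM, and it is quite likely that this assay again reports only a limit.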

Compound 3, half-maximal inhibitory concentration: > 10000 nM
Compound 3 ended at the assay's limit (the forecaster's own chance of this, stated with the estimate: 75%); the middle value lies beyond the limit too.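

In this assay compound 3 gives > 10000 nM, which is a limit of the assay and not a number. No step can be read between compound 2 and compound 3, because both stop at the same limit: the limit of > 10000 nM in this assay, at which 3 of the 3 values shown sit. The compounds shown leave open how strongly either compound inhibits, and whether 2-(ethoxycarbonyl)ethenyl in place of propoxycarbonyl makes any difference.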